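Swapping Chloro for Trifluoromethyl on the Phenyl Ring

The source may hold more compounds than are shown below. What is called first, only, known or untested is meant among the compounds shown, and "the series" means these compounds.

Among the measured compounds shown here, compound 1 `Cn1ncc2c(NC(=O)NCc3cc(C(F)(F)F)nn3-c3cccc(Cl)c3)cccc21` gives 2.3 nM in an assay on CHO-K1 cells for antagonist activity at transient receptor potential cation channel subfamily V member 1 (Homo sapiens), read by FLIPR and calcium flux, with a stated time of 6 min (on this read-out lower numbers stand for stronger inhibition and higher numbers for weaker inhibition), the lowest of the two numbers measured so far. Compound 2 `CC(=O)n1ncc2c(NC(=O)NCc3cc(C(F)(F)F)nn3-c3cccc(Cl)c3)cccc21` gives 17.4 nM in this assay, and the step of a 7.6-fold higher number from compound 1 to compound 2 (0.88 log units; beyond the scatter) is modest. Compound 3 `Cn1ncc2c(NC(=O)NCc3cc(C(F)(F)F)nn3-c3cccc(C(F)(F)F)c3)cccc21` differs from compound 1 by trifluoromethyl in place of chloro on an aromatic carbon, which one bond further out reads as 3-chlorophenyl to 3-(trifluoromethyl)phenyl. For the measured compounds named here, the only measured step concerns a different place, the aromatic nitrogen, so no measured step bears directly on this change. A step within the scatter is therefore expected: compound 3 is estimated at 3 nM, between 1 nM and 9 nM, meaning a 1.3-fold higher number from compound 1 to compound 3 (0.12 log units; within the scatter).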

Compound 3, inhibition constant: 1.4 nM
Compound 3: the middle estimate sits 2.1-fold (0.33 log units) above what was measured; the measured number falls inside the stated range.
By their numbers in this assay, from the lowest: compounds 3 and 1 (each within the scatter of the next); then compound 2.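

Trifluoromethyl in place of chloro on this aromatic carbon gives a 1.6-fold lower number from compound 1 to compound 3 (0.22 log units; within the scatter) and so, although 4 heavy atoms replace 1, the two groups cannot be told apart at this position. Among the compounds shown here, this is the first reading on the phenyl ring, since the earlier step concerned the aromatic nitrogen. No measurement here explains why the two groups read alike. Going by these compounds, whether an amine or a carboxylic acid on this carbon would read the same stays open. Also open, on these data alone, is whether this swap would read alike with the acetyl of compound 2 on the aromatic nitrogen.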